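Amide series: from compound 3 to compound 4

This account rests on a few compounds, and the source may have more. Where it says the series, first, only, none or still open, it means among the compounds named here.

Measured values in an ADME assay on microsomes from liver (Mus musculus) for pharmacokinetics, read by LC-MS, using NADPH, with stated times of 5 min, 15 min and 30 min, tested at 10 uM (a lower number here means slower removal, a higher number faster removal of the compound), are as follows
- compound 1 `C[C@@H](c1ccc(NC(=O)N2CC(c3cccnc3)C2)cc1)N1Cc2ccccc2C1=O` gives 123 mL.min-1.g-1
- compound 2 `C[C@H](NC(=O)C1CCOCC1)c1ccc(NC(=O)N2CC(c3cccnc3)C2)cc1` gives 58 mL.min-1.g-1
- compound 3 `C[C@H](NC(=O)[C@@H]1CCCN1C)c1ccc(NC(=O)N2CC(c3cccnc3)C2)cc1` gives 40.8 mL.min-1.g-1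

Compound 3 sits at the low end of these three numbers, with a 3.0-fold lower number from compound 1 to compound 3 (0.48 log units; beyond the scatter) and a 1.4-fold lower number from compound 2 to compound 3 (0.15 log units; within the scatter). The next structure is compound 4 `CCC(=O)N[C@@H](C)c1ccc(NC(=O)N2CC(c3cccnc3)C2)cc1`, and the change is ethyl in place of 1-methylpyrrolidin-2-yl on a carbonyl carbon, in words ethyl in place of 1-methylpyrrolidin-2-yl on a carbonyl carbon.

Going by the values given here, the closest precedent is the exchange on that same carbonyl carbon, a 1.4-fold lower number from compound 2 to compound 3 (0.15 log units; within the scatter), which stayed within the scatter. The two modest steps, a 2.1-fold lower number from compound 1 to compound 2 (0.33 log units; beyond the scatter) and a 3.0-fold lower number from compound 1 to compound 3 (0.48 log units; beyond the scatter), concern a different exchange, on a saturated chain carbon, and bear on this change only loosely. Among the compounds with values here, no measured compound carries ethyl here, so the direction is open. In this assay no step beyond the scatter is therefore expected. The expected step is a 1.1-fold higher number from compound 3 to compound 4 (0.04 log units; within the scatter). Compound 4 is estimated at 45 mL.min-1.g-1, with an expected range of 22 mL.min-1.g-1 to 90 mL.min-1.g-1.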

Compound 4, intrinsic clearance in microsomes: 31.4 mL.min-1.g-1
Compound 4: the middle estimate sits 1.4-fold (0.16 log units) above what was measured, within the range that was stated.
By their numbers in this assay, from the lowest: compounds 4, 3 and 2 (each within the scatter of the next); then compound 1.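

With ethyl on the carbonyl carbon, a 1.3-fold lower number from compound 3 to compound 4 (0.11 log units; within the scatter) and a 1.8-fold lower number from compound 2 to compound 4 (0.27 log units; within the scatter) show in this assay that neither the 1-methylpyrrolidin-2-yl ring nor the oxan-4-yl ring is needed at this place to keep the number in this range. What remains beyond the scatter is a 3.9-fold lower number from compound 1 to compound 4 (0.59 log units; beyond the scatter) and this exchange sits on the saturated chain carbon, not on the carbonyl carbon. No measurement on hand gives a reason for any of these steps.

On these data alone, whether a longer chain such as n-butyl, an amine or a carboxylic acid on the carbonyl carbon would move the number beyond the scatter stays open. Also open, as far as these compounds go, is whether any change to the shared core outside this amide would take the number further down.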